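Changing the side chain of compound 1

A few compounds are considered here, and "the series" means these few. Any claim that something is new, unique, unknown or untested is made for them only; others in the source may bear on it.

Compound 1 `O=C(/C=C/c1ccc(NC(=O)Nc2ccc(Cl)c(C(F)(F)F)c2)cc1)NC1CCC1`: 17300 nM
Compound 2 `CC(NC(=O)CCc1ccc(NC(=O)Nc2ccc(Cl)c(C(F)(F)F)c2)cc1)c1ccccc1`: > 50000 nM
Compound 3 `CC(NC(=O)c1ccc(-c2ccc(NC(=O)Nc3cc(C(F)(F)F)ccc3Cl)cc2)cc1)c1ccccc1`: 16800 nM

All three compounds were tested in a functional assay on KETR3 cells (Homo sapiens) for inhibition, read by MTT assay, with a stated time of 120 h; a lower number here means a stronger inhibitor, a higher number a weaker inhibitor. In this assay compound 1 gives 17300 nM and compound 3 gives 16800 nM, two readings within the usual scatter of each other. Compound 2 gives > 50000 nM, which is a limit of the assay and not a number. Among the measured compounds shown here, compound 1 therefore shares its place with compound 3, and these two hold the only true numbers so far.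

Compound 4 `CNC(=O)C#Cc1ccc(NC(=O)Nc2ccc(Cl)c(C(F)(F)F)c2)cc1` has not yet been measured. It differs from compound 1 in one place, on an aromatic carbon: 2-(methylcarbamoyl)ethynyl in place of 2-(cyclobutylcarbamoyl)ethenyl on an aromatic carbon. In words, 2-(methylcarbamoyl)ethynyl stands in place of 2-(cyclobutylcarbamoyl)ethenyl, and the rest of the core of compound 1 stays the same.

For the measured compounds named here, no two measured compounds differ in only one place, so nothing here shows directly what such a swap does. In this assay the expectation is therefore no change beyond the scatter, with no favoured direction, and it starts from compound 1 at 17300 nM. The estimated change is a 1.0-fold higher number from compound 1 to compound 4 (0.02 log units; within the scatter). Compound 4 is expected near 18000 nM, with an estimated range from 6000 nM to 48000 nM.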

Compound 4, half-maximal inhibitory concentration: 24700 nM
Compound 4: the middle estimate sits 1.4-fold (0.14 log units) below what was measured; low and high end bracket the measured number.
By their numbers in this assay, from the lowest: compounds 3, 1 and 4 (each within the scatter of the next). At a limit, above all of these: compound 2.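

In this assay the swap gives a 1.4-fold higher number from compound 1 to compound 4 (0.15 log units; within the scatter), so the readings for these two compounds cannot be told apart. This is the first pair shown that differs in one place, and it shows that, on this aromatic carbon, the smaller 2-(methylcarbamoyl)ethynyl can stand in place of 2-(cyclobutylcarbamoyl)ethenyl with no change beyond the scatter, even though the four-membered ring is gone and a triple bond replaces one of the double bonds. Compound 2 remains the only compound at a limit of the assay, which is not a number: the limit of > 50000 nM in this assay, at which 1 of the 4 values shown sits.

The swap alters the ring, the link to the aromatic ring and the size of the group all at once, so this single pair cannot separate what each of these contributes, or show whether their contributions offset one another. It also leaves open whether a different group at this position, such as an amine, a carboxylic acid or a longer chain, would move the number beyond the scatter in either direction.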